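A few compounds are considered here, and "the series" means these few. Any claim that something is new, unique, unknown or untested is made for them only; others in the source may bear on it.

Compound 2 `Cc1ccc(-c2ccc(NC(=O)c3ccccc3)nc2)cc1` gives 51% in an assay on isolated protein (Aquatica lateralis) for inhibition of Luciferin 4-monooxygenase (Luciola lateralis), read by a luciferase reporter, tested at 10 uM (on this read-out higher numbers stand for more inhibition at the one concentration tested (going by the name of the read-out) and lower numbers for less inhibition), the higher of the two numbers seen so far; compound 1 `O=C(Nc1ccccn1)c1ccccc1` gives 27% in this assay. Among the measured compounds shown here, the only measured step, a number 24 percentage points higher from compound 1 to compound 2 (beyond the scatter), introduces a whole aryl group and does not touch the change now considered. Compound 3 `CN(C)c1ccc(-c2ccc(NC(=O)c3ccccc3)nc2)cc1` differs from compound 2 by dimethylamino in place of methyl on an aromatic carbon. For the measured compounds named here, no measured step bears on this exchange, so no step beyond the scatter is expected in this assay. Compound 3 is therefore estimated at 50% in this assay, between 30% and 70%, with an expected step of a number 1 percentage points lower from compound 2 to compound 3 (within the scatter).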

Compound 3, a percentage reported as inhibition, at one concentration (the size of the read-out at that concentration, not a potency): 14%
The estimate for compound 3 lay 36 percentage points above the measured number, and the stated range ends above it.
By their numbers in this assay, from the lowest: compound 3; then compound 1; then compound 2.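

In this assay, the step of a number 37 percentage points lower from compound 2 to compound 3 (beyond the scatter) shows that the aromatic carbon para to a large group is sensitive to the group it carries. The earlier compounds shown here, with only methyl there, could not show this. Nothing measured on this change accounts for the loss. On these data alone, it remains open whether the drop belongs to dimethylamino alone or extends to other groups at this place. A primary amine, a methoxy group or a longer alkyl chain there would help to separate the nitrogen from the size of the group.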